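Extending a Methyl Ester by One Carbon

The compounds below may be only part of what the source reports. "The series", "measured", "known", "first", "only" and "open" are said of these compounds alone.

Compound 2 `COC(=O)c1ccc(-c2cc(N3CCC(CCNS(N)(=O)=O)CC3)ncn2)cc1` gives the lower of the two numbers recorded in a functional assay on HT-29 cells (Homo sapiens) for antiproliferative activity, read by sulforhodamine B assay, with a stated time of 48 h (a lower number here means a stronger inhibitor of growth, a higher number a weaker inhibitor of growth), where compound 2 gives 19600 nM, though the gap to compound 1 is within the scatter. Compound 1 `NS(=O)(=O)NCCC1CCN(c2cc(-c3ccc(C(F)(F)F)cc3)ncn2)CC1` carries a trifluoromethyl in place of the methoxycarbonyl on the aromatic carbon, and in this assay compound 1 gives 22600 nM. Among the measured compounds shown here, the step of a 1.2-fold lower number from compound 1 to compound 2 (0.06 log units; within the scatter) is the only measured step, and since it lies within the scatter the two compounds cannot be ranked.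

Compound 3 `CCOC(=O)c1ccc(-c2cc(N3CCC(CCNS(N)(=O)=O)CC3)ncn2)cc1` takes one further step from compound 2: methyl in place of hydrogen on a saturated chain carbon bound to an oxygen next to a carbonyl group, so the methoxycarbonyl becomes an ethoxycarbonyl. The step from compound 1 to compound 2 is the only one that bears on this, as it altered the same group, and it produced nothing beyond the scatter; it was, however, a swap of the whole group rather than a lengthening of it, so it gives only weak guidance. No shift beyond the scatter is expected in either direction. Compound 3 is therefore estimated at 19000 nM in this assay, with a range from 8000 nM to 45000 nM. The expected step is then a 1.0-fold lower number from compound 2 to compound 3 (0.01 log units; within the scatter).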

Compound 3, concentration for 50% growth inhibition: 6800 nM
For compound 3 the middle estimate is 2.8-fold (0.45 log units) above the measured one, and the stated range ends above it.
By their numbers in this assay, from the lowest: compound 3; then compounds 2 and 1 (each within the scatter of the next).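

In this assay the change from methoxycarbonyl to ethoxycarbonyl gives a 2.9-fold lower number from compound 2 to compound 3 (0.46 log units; beyond the scatter), so one added methyl, on a saturated chain carbon bound to an oxygen next to a carbonyl group, moves the number beyond the scatter, whereas the whole-group swap of a 1.2-fold lower number from compound 1 to compound 2 (0.06 log units; within the scatter) did not. Ethoxycarbonyl also separates from trifluoromethyl, with a 3.3-fold lower number from compound 1 to compound 3 (0.52 log units; beyond the scatter), which leaves compound 3 as the one compound of the three whose steps to both others lie beyond the scatter, although both of those steps are modest. Nothing available explains why so small an addition changes the growth-inhibition number in these cells.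

A single lengthening cannot show whether the number keeps falling as the chain grows, and a propoxycarbonyl or a branched isopropoxycarbonyl group would test whether the gain continues or stops at ethoxycarbonyl. On these data alone, it also remains open whether the ester itself matters or only the size of the group, a question that a carboxylic acid or a simple ethyl ketone at the same carbon could help to settle.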